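Octyl for 2-chlorophenyl on the acyl carbonyl

A few compounds are considered here, and "the series" means these few. Any claim that something is new, unique, unknown or untested is made for them only; others in the source may bear on it.

In a functional assay on NCI-H23 cells (Homo sapiens) for cytotoxicity, read by sulforhodamine B assay, with a stated time of 72 h (a higher number here means a weaker inhibitor of growth, a lower number a stronger inhibitor of growth), compound 1 (`O=C(Nc1ccccc1O)C1CCc2ccccc2N1C(=O)c1ccccc1Cl`) gives 46900 nM. Compound 3 (`O=C(Nc1cc(C(F)(F)F)cc(C(F)(F)F)c1)C1CCc2ccccc2N1C(=O)c1ccc(Cl)cc1`) gives 889 nM. Compound 1 therefore holds the higher of the two numeric values in the series, and the gap between the pair lies beyond the usual scatter. Compound 2 (`O=C(Nc1ccc(O)cc1)C1CCc2ccccc2N1`) reads > 100000 nM, which is a limit of the assay and not a number.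

The next compound to be read is compound 4 (`CCCCCCCCC(=O)N1c2ccccc2CCC1C(=O)Nc1ccccc1O`). It keeps the core of compound 1 and its amide side, and it carries octyl in place of 2-chlorophenyl on a carbonyl carbon.

Going by the values given here, no measured pair isolates this change, so the expectation is anchored on compound 1 at 46900 nM and carries wide uncertainty. In this assay no step beyond the scatter is expected, with only a slight lean towards a lower number. The expected change is a 1.2-fold lower number from compound 1 to compound 4 (0.09 log units; within the scatter). A larger move in either direction cannot be excluded on the present data. For compound 4 the estimated value is 38000 nM, with an expected range from 11000 nM to 100000 nM.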

Compound 4, concentration for 50% growth inhibition: 55800 nM
Compound 4: the middle estimate sits 1.5-fold (0.17 log units) below what was measured; low and high end bracket the measured number.
By their numbers in this assay, from the lowest: compound 3; then compounds 1 and 4 (each within the scatter of the next). At a limit, above all of these: compound 2.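

In this assay the exchange on the carbonyl carbon bound to the ring amide-type nitrogen gives a 1.2-fold higher number from compound 1 to compound 4 (0.08 log units; within the scatter), so compound 1 and compound 4 cannot be told apart at this position. Going by these compounds alone, this is the first pair to isolate a change at this position, and it shows that, with this amide side, 2-chlorophenyl can give way to octyl, a chain with no ring and no chlorine, without a read-out beyond the scatter. Compound 4, like compound 1, still reads as a number, while compound 2 alone stands at a limit, which is not a number: the limit of > 100000 nM in this assay, at which 1 of the 4 values shown sits.

This single pair lies in the weak part of the series and says nothing about whether the same exchange would remain silent with the amide side of compound 3, which gives 889 nM. Also open, on these data alone, is whether a butyl chain, or an octyl chain ending in an amine or a carboxylic acid, would read differently on this carbonyl.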